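The compounds below may be only part of what the source reports. "The series", "measured", "known", "first", "only" and "open" are said of these compounds alone.

Measured so far:
compound 1, `COc1cc(/C=N/NC(=O)CSc2nc3ccccc3s2)cc(OC)c1OC`: in a functional assay on BCG823 cells (Homo sapiens) for inhibition, read by MTT assay, with a stated time of 72 h (on this read-out higher numbers stand for weaker inhibition and lower numbers for stronger inhibition), compound 1 gives > 80 ug/mL
compound 2, `C/C(=N\NC(=O)c1ccc(CSc2nc3ccccc3s2)cc1)c1ccc(C)c([N+](=O)[O-])c1`: in this assay compound 2 gives > 80 ug/mL

Compound 1 stands at a limit of the assay, not a measured number. Compound 2 likewise stands at a limit of the assay rather than a number. Taken together, every value so far sits at the limit of > 80 ug/mL in this assay, at which 2 of the 2 values shown sit, so nothing separates the two measured compounds and no step between them can be given a size.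

Compound 3, `C/C(=N\NC(=O)c1ccc(CSc2nc3ccccc3s2)cc1)c1ccc([N+](=O)[O-])cc1`, has not yet been measured in this assay. It differs from compound 2 in one place: 4-nitrophenyl in place of 4-methyl-3-nitrophenyl on a carbon with a double bond to nitrogen. Within the data shown here, with no measured step between compounds to lean on, the expected step is a step that the limit leaves unreadable from compound 2 to compound 3, which amounts to no change beyond the usual scatter. Compound 3 is therefore estimated to give 90 ug/mL, within a range from 40 ug/mL to 200 ug/mL, and most likely to come back as a limit once more.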

Compound 3, half-maximal inhibitory concentration: 31.3 ug/mL
Beside the measured number, compound 3's estimate is 2.9-fold (0.46 log units) above it; measured number below the stated range.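

Among these compounds, this is the first change that separates two compounds: in this assay, 4-nitrophenyl in place of 4-methyl-3-nitrophenyl on a carbon with a double bond to nitrogen gives an at least 2.5-fold lower number from compound 2 to compound 3 (0.40 log units; beyond the scatter) and so shows that the read-out responds to this position. The two groups differ only by the methyl group, so a small edit here is enough to bring a compound off the limit to a measured number, and a lower number means stronger inhibition. The true size of the step remains unknown, because compound 2 stands at a limit of the assay and not at a number: the limit of > 80 ug/mL in this assay, at which 2 of the 3 values shown sit.

On these data alone, it remains open what an amine or a carboxylic acid in place of the nitro group would do to the read-out. Compound 1 differs from compound 3 in more than one place, so it cannot show whether the same change would act on another core.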